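Aminophenyl for hydroxyphenyl: expected shift for compound 3

This account rests on a few compounds, and the source may have more. Where it says the series, first, only, none or still open, it means among the compounds named here.

Compound 1 `O=C(NCC(=O)N1[C@@H](c2ccccc2)CC[C@H]1C(=O)O)[C@@H](S)Cc1ccc(O)cc1` gives 3.4 nM in an assay on isolated protein for inhibition of Neprilysin (Oryctolagus cuniculus); a higher number here means a weaker inhibitor, a lower number a stronger inhibitor. Among the measured compounds shown here, compound 2 `O=C(NCC(=O)N1[C@@H](c2cccc(O)c2)CC[C@H]1C(=O)O)[C@@H](S)Cc1ccc(O)cc1`, which carries a 2.1-fold lower number from compound 1 to compound 2 (0.33 log units; beyond the scatter), gives 1.6 nM and stands at the lowest of the two numbers so far, with compound 1 as its nearest neighbour. Compound 3 `Nc1ccc([C@H]2CC[C@@H](C(=O)O)N2C(=O)CNC(=O)[C@@H](S)Cc2ccc(O)cc2)cc1` differs from compound 2 by 4-aminophenyl in place of 3-hydroxyphenyl on a saturated ring carbon; in words, 4-aminophenyl in place of 3-hydroxyphenyl on a saturated ring carbon. The only measured step on this ring position is the one from compound 1 to compound 2, and it was modest; no measured step exchanges one substituent of this ring for another, so the direction of the new change is not backed by a shown comparison. The expected step is a 1.6-fold higher number from compound 2 to compound 3 (0.21 log units; within the scatter), small and most likely within or only just beyond the scatter. Compound 3 is therefore estimated at 2.6 nM, with a range from 1 nM to 7 nM.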

Compound 3, half-maximal inhibitory concentration: 26 nM
Compound 3: the middle estimate sits 10-fold (1.00 log units) below what was measured, and the stated range ends below it.
By their numbers in this assay, from the lowest: compound 2; then compound 1; then compound 3.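

In this assay, the aryl substituent at this position can matter far more than the step from phenyl to 3-hydroxyphenyl suggested: the move to 4-aminophenyl gives a 16-fold higher number from compound 2 to compound 3 (1.21 log units; beyond the scatter), and adding the amino group to the phenyl ring gives a 7.6-fold higher number from compound 1 to compound 3 (0.88 log units; beyond the scatter). The hydroxy and amino substituents therefore move the number in opposite directions from the unsubstituted phenyl, even though 3-hydroxyphenyl and 4-aminophenyl have the same counts of heavy atoms, hydrogen-bond donors and hydrogen-bond acceptors. No measurement here accounts for the size of this shift.

As far as these compounds go, the step between compound 2 and compound 3 changes both the heteroatom and its place on the aromatic ring, so the contribution of each remains open. The 3-aminophenyl and 4-hydroxyphenyl groups would separate these two changes.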